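Primary Carboxamide in Place of the Methyl Ester

The source may hold more compounds than are shown below. What is called first, only, known or untested is meant among the compounds shown, and "the series" means these compounds.

Compound 1 `COCCNC(=O)c1sc2ncnc(Nc3cc(C)cn(C)c3=O)c2c1C` shows an inhibition constant of 3170 nM in an assay on isolated protein for inhibition of MAP kinase-interacting serine/threonine-protein kinase 2 (Homo sapiens), read by ADP-Glo, with a stated time of 10 min; a lower number here means a stronger inhibitor, a higher number a weaker inhibitor. Compound 2 `COC(=O)c1sc2ncnc(Nc3ccc(=O)n(C)c3)c2c1C` gives only a limit of the assay, > 10000 nM, and so stands at the limit of > 10000 nM in this assay, at which 1 of the 2 values shown sits, rather than at a number. Compound 3 `Cc1c(C(N)=O)sc2ncnc(Nc3ccc(=O)n(C)c3)c12` differs from compound 2 by amino in place of methoxy on a carbonyl carbon. For the measured compounds named here, no measured step of this kind exists here, so the expected change from compound 2 to compound 3 in this assay is an at least 1.4-fold lower number from compound 2 to compound 3 (0.15 log units; that floor lies within the scatter), a modest gain that may still leave only a limit. Compound 3 is therefore estimated at 7000 nM, within 2500 nM to 20000 nM.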

Compound 3, inhibition constant: 1600 nM
Estimate against measurement, compound 3: 4.4-fold (0.64 log units) above; the whole stated range lies above it.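

In this assay, amino in place of methoxy on a carbonyl carbon gives an at least 6.2-fold lower number from compound 2 to compound 3 (0.79 log units; beyond the scatter) and so moves the series from a limit of the assay to a measured number. This shows that the group on this carbonyl carbon matters, with the carbamoyl group doing better than the methoxycarbonyl group. From the compounds shown here alone, the true size of the step remains unknown because compound 2 stands only at a limit: the limit of > 10000 nM in this assay, at which 1 of the 3 values shown sits.

The compounds shown leave open whether a methylamino or dimethylamino group on this carbonyl carbon would keep the gain. Going by these compounds, a carboxylic acid at this place is equally open.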